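Nitro in place of trifluoromethyl: working notes

The source may report more compounds than this note shows. Statements on the series, on what has been measured and on what is new or still open speak of the compounds shown alone.

In a functional assay on NCI-H661 cells (Homo sapiens) for antiproliferative activity, read by MTT assay, with a stated time of 72 h (a higher number here means a weaker inhibitor, a lower number a stronger inhibitor), compound 1 `O=C(CCCCCCc1nc(-c2ccc(C(F)(F)F)cc2)no1)NO` gives 15300 nM and compound 2 `Nc1ccccc1NC(=O)CCCCCCc1nc(-c2ccc(C(F)(F)F)cc2)no1` gives 29800 nM. Compound 2 therefore stands level with compound 1 within the scatter, and the series offers no separation between them. The next step leads to compound 3 `Nc1ccccc1NC(=O)CCCCCCc1nc(-c2ccc([N+](=O)[O-])cc2)no1`, with nitro in place of trifluoromethyl on an aromatic carbon. Within the data shown here, the only measured step, a 1.9-fold higher number from compound 1 to compound 2 (0.29 log units; within the scatter), lies within the scatter, but it concerns 2-aminophenyl in place of hydroxy on an amide-type nitrogen. Among the measured compounds shown here, no measured pair tests the group on the aromatic carbon, so that step bears only indirectly on this change. With so little evidence, no shift in either direction beyond the scatter is expected in this assay, and the range stays wide. The estimated 1.2-fold lower number from compound 2 to compound 3 (0.08 log units; within the scatter) is expected to remain within the scatter. Compound 3 is expected at 25000 nM, within an estimated range of 10000 nM to 60000 nM.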

Compound 3, half-maximal inhibitory concentration: > 100000 nM
Compound 3 gave a limit, no number (the forecaster's own chance of this, stated with the estimate: 8%); middle value at least 4.0-fold (0.60 log units) away from the limit.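

In this assay, among these compounds, nitro in place of trifluoromethyl gives an at least 3.3-fold higher number from compound 2 to compound 3 (0.52 log units; beyond the scatter), the only step so far that lies beyond the scatter. The reading for compound 3 is a limit of the assay and not a number: the limit of > 100000 nM in this assay, at which 1 of the 3 values shown sits. The group on this aromatic carbon therefore matters to the read-out in this assay, which compound 1 and compound 2 could not show, as both carry the 4-(trifluoromethyl)phenyl group.

The compounds shown leave open how an amine or a methoxy group at this position would read, so a single pair cannot say whether the step is particular to nitro. Also open, from the compounds shown here alone, is whether nitro gives a similar step when the 2-aminophenyl on the amide-type nitrogen is replaced by the hydroxy of compound 1.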